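A Pyridyl Group in Place of Methylpiperazine

A few compounds are considered here, and "the series" means these few. Any claim that something is new, unique, unknown or untested is made for them only; others in the source may bear on it.

Compound 1, `Cc1cc(C)c(NC(=O)N(Cc2ccc(N3CCN(C)CC3)cc2)C2CCCCCC2)c(C)c1`, in a functional assay on a cell-free system (plasma) with sterol O-acyltransferase, Soat (Rattus norvegicus) as the target; a higher number here means that more compound is needed for the effect, a lower number that less compound is needed: compound 1 gives > 1 mg/kg, which is a limit of the assay and not a number.
Compound 2, `CN(C)c1ccc(CN(Cc2cccc(-c3cc[nH]n3)c2)C(=O)Nc2c(F)cc(F)cc2F)cc1`, in this assay: compound 2 gives < 0.32 mg/kg, also a limit of the assay.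
Compound 3, `COc1ccc(CN(Cc2cccc(-c3cc[nH]n3)c2)C(=O)Nc2c(SC)cc(C)nc2SC)cc1`, in this assay: compound 3 gives < 0.1 mg/kg, again a limit of the assay.

Compound 1 therefore stands at the weak end of what is known: its result sits at the limit of > 1 mg/kg in this assay, at which 1 of the 3 values shown sits, while compound 2 sits at the limit of < 0.32 mg/kg in this assay, at which 1 of the 3 values shown sits, and compound 3 at the limit of < 0.1 mg/kg in this assay, at which 1 of the 3 values shown sits. Within the data shown here, compounds 2 and 3 share neither the core nor the amide-bearing aryl group of compound 1, so they offer no step to compare against, and only their positions at their own limits can be stated.

Compound 4, `Cc1cc(C)c(NC(=O)N(Cc2ccc(-c3ccccn3)cc2)C2CCCCCC2)c(C)c1`, differs from compound 1 in one place: pyridin-2-yl in place of 4-methylpiperazin-1-yl on an aromatic carbon. Among the measured compounds shown here, no measured pair reports the effect of such a change, and no line of measured evidence connects the groups involved to the read-out. The step from compound 1 to compound 4 in this assay is expected to be small, a number no higher from compound 1 to compound 4 (the limit leaves the size open), not clearly beyond the scatter in either direction. Compound 4 is estimated at 1 mg/kg, within a range from 0.3 mg/kg to 3 mg/kg.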

Compound 4, dose for half-maximal effect: > 1 mg/kg
Compound 4: a limit, no number (the forecaster's own chance of this, stated with the estimate: 55%); the middle value lies on the limit itself.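

In this assay compound 4 gives > 1 mg/kg, a limit of the assay and not a number. Compound 1 gives > 1 mg/kg, also a limit, and no step can be read between compound 1 and compound 4. The compounds shown leave open whether pyridin-2-yl in place of 4-methylpiperazin-1-yl changes the read-out at all, and by how much.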